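The source may hold more compounds than are shown below. What is called first, only, known or untested is meant among the compounds shown, and "the series" means these compounds.

Working notes on the series, read in a functional assay on K562 cells (Homo sapiens) for antiproliferative activity, read by MTT assay, with a stated time of 48 h; on this read-out higher numbers stand for weaker inhibition and lower numbers for stronger inhibition. Compound 1 `COc1ccc(N2CCN(Cc3ccc4c(c3O)-c3ccc(cc3O)CCc3ccc(O)c(c3)Oc3ccc(cc3)CC4)CC2)cc1` is reported only as a limit, > 20000 nM. Compound 2 `Oc1ccc2cc1Oc1ccc(cc1)CCc1ccc(CN3CCN(Cc4ccccc4)CC3)c(O)c1-c1ccc(cc1O)CC2` is also reported only as a limit, > 20000 nM. Compound 3 `CCCCN(CCCC)Cc1ccc2c(c1O)-c1ccc(cc1O)CCc1ccc(O)c(c1)Oc1ccc(cc1)CC2` likewise gives only a limit, > 20000 nM. Among the compounds with values here, the series so far therefore offers (the limit of > 20000 nM in this assay, at which 3 of the 3 values shown sit), and compound 2 stands with the other two compounds, with no number that would place it.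

The next entry is compound 4 `CC(C)(C)OC(=O)N1CCN(Cc2ccc3c(c2O)-c2ccc(cc2O)CCc2ccc(O)c(c2)Oc2ccc(cc2)CC3)CC1`, which has tert-butoxycarbonyl in place of benzyl on an amine nitrogen in a ring.

Within the data shown here, the one measured step at this nitrogen is a step that the two limits leave unreadable from compound 1 to compound 2. It provides neither a size nor a direction to carry over. Among the measured compounds shown here, compound 3 carries no comparable step, so it adds only its limit. For the measured compounds named here, no measured compound carries tert-butoxycarbonyl, and the data do not show what this group does in this assay.

The working expectation is that compound 4 stays at the same limit, with no readable gain or loss. The expected change is a step that the limit leaves unreadable from compound 2 to compound 4, and it is only a nominal estimate. For compound 4 the estimated value is 25000 nM, with an expected range of 12000 nM to 50000 nM.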

Compound 4, half-maximal inhibitory concentration: > 20000 nM
Compound 4 gave a limit, no number (the forecaster's own chance of this, stated with the estimate: 75%); the middle value does not contradict the limit.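

Compound 4, like compound 1 and compound 2, is reported in this assay only as a limit, so neither new step, from compound 2 or from compound 1 to compound 4, can be read: the limit of > 20000 nM in this assay, at which 4 of the 4 values shown sit.

The compounds shown leave open how benzyl, 4-methoxyphenyl and tert-butoxycarbonyl on this amine nitrogen compare, with no number for any of them.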